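Replacing an Ethylcarbamoyl Group with Nitro: What to Expect

A few compounds are considered here, and "the series" means these few. Any claim that something is new, unique, unknown or untested is made for them only; others in the source may bear on it.

Of the compounds shown here, two with a shared core have been measured in an assay on COS-7 cells for inhibition of patatin-like phospholipase domain-containing protein 2 (Mus musculus); a lower number here means a stronger inhibitor, a higher number a weaker inhibitor. Compound 1 `CCCCOC(=O)c1cccc(-c2ccc(OCC)cc2)c1` carries a butoxy group on its carbonyl carbon, and in this assay compound 1 gives 100000 nM. Compound 2 `CCNC(=O)c1cccc(-c2ccc(OCC)cc2)c1` carries an ethylamino group in that place instead, and in this assay compound 2 gives 90000 nM. The step of a 1.1-fold lower number from compound 1 to compound 2 (0.05 log units; within the scatter) shows that this exchange left the number essentially where it was, so compound 2 stands beside compound 1 within the scatter, and both numbers are very high, which means very weak inhibition.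

Compound 3 `CCOc1ccc(-c2cccc([N+](=O)[O-])c2)cc1` has not yet been measured. It differs from compound 2 in one place: nitro in place of ethylcarbamoyl on an aromatic carbon. Among the compounds with values here, no measured step bears directly on this change; the only known step, a 1.1-fold lower number from compound 1 to compound 2 (0.05 log units; within the scatter), altered a substituent on the carbonyl carbon rather than removing the whole carbonyl-bearing group, and it was within the scatter. With nothing pointing toward a gain, the expectation rests on compound 2 giving 90000 nM. Compound 3 is therefore expected to give about 100000 nM, with a range from 30000 nM to 300000 nM. The expected step of a 1.1-fold higher number from compound 2 to compound 3 (0.05 log units; within the scatter) is estimated to lie within the scatter.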

Compound 3, half-maximal inhibitory concentration: > 200000 nM
Compound 3 gave a limit, no number; the forecaster's own chance of this, stated with the estimate: 40%; middle value at least 2.0-fold (0.30 log units) away from the limit.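

In this assay, compound 3 gives a limit and not a number: the limit of > 200000 nM in this assay, at which 1 of the 3 values shown sits. Even so, the exchange of ethylcarbamoyl for nitro on this aromatic carbon can be read in one direction, as an at least 2.2-fold higher number from compound 2 to compound 3 (0.34 log units; beyond the scatter), so replacing the whole group makes inhibition weaker by more than the scatter, whereas changing only the substituent on the carbonyl carbon left the number essentially unchanged. The exchange of butoxycarbonyl for nitro gives an at least 2.0-fold higher number from compound 1 to compound 3 (0.30 log units; that floor lies within the scatter), and as that floor lies within the scatter, this second comparison does not by itself set the two compounds apart.

The compounds shown leave open how far compound 3 really lies from the other two, and whether the carbonyl itself matters at this position or some other feature of the groups that carry it. A carboxylic acid or an amine on the same aromatic carbon would help show whether any group there can bring the number down from the very weak range in which all three compounds sit.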